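The compounds below may be only part of what the source reports. "The series", "measured", "known", "first", "only" and "open" are said of these compounds alone.

Compound 3 `CCC(C)[C@H](NC[C@H](C)N)c1cc(C(F)(F)F)ccc1N1CCN(C(=O)CCc2ccc(Cl)cc2Cl)CC1` gives the lowest number of the three measured compounds in an assay on HEK293 cells for displacement of a labelled ligand from Melanocortin receptor 4 (Homo sapiens) (a lower number here means a stronger inhibitor, a higher number a weaker inhibitor), at 89 nM. Compound 2 `COc1ccc(CCC(=O)N2CCN(c3ccc(C(F)(F)F)cc3[C@@H](N)CC(C)C)CC2)cc1` gives 350 nM in this assay, and compound 1 `CC(C)C[C@H](N)c1cc(C(F)(F)F)ccc1N1CCN(C(=O)CCc2ccccc2Cl)CC1` gives 1700 nM. Within the data shown here, the only step between measured compounds that differ in one place is a 4.9-fold lower number from compound 1 to compound 2 (0.69 log units; beyond the scatter), which concerns the aryl group on a saturated chain carbon and does not touch the part altered here.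

Compound 4 `CC(C)C[C@H](NC(=O)CCN)c1cc(C(F)(F)F)ccc1N1CCN(C(=O)CCc2ccc(Cl)cc2Cl)CC1` is made from compound 3 by 1-(((2-aminoethyl)carbonyl)amino)-3-methylbutyl in place of 1-((2-aminopropyl)amino)-2-methylbutyl on an aromatic carbon. The side chain attached through the amine is exchanged for one attached through a carbonyl, and the branching of the alkyl part shifts, with one defined stereocentre less. Among the measured compounds shown here, compounds 1 and 2 carry only a plain amine there, but they also differ from compound 3 in the aryl group, so no measured step isolates this change.

With no direct guide, a modest weakening is expected, a 2.8-fold higher number from compound 3 to compound 4 (0.45 log units; beyond the scatter). Compound 4 is therefore estimated at 250 nM, with a range from 60 nM to 1000 nM.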

Compound 4, inhibition constant: 25 nM
Compound 4: the middle estimate sits 10-fold (1.00 log units) above what was measured; the whole stated range lies above it.
By their numbers in this assay, from the lowest: compound 4; then compound 3; then compound 2; then compound 1.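

In this assay, putting 1-(((2-aminoethyl)carbonyl)amino)-3-methylbutyl in place of 1-((2-aminopropyl)amino)-2-methylbutyl on the aromatic carbon gives a 3.6-fold lower number from compound 3 to compound 4 (0.55 log units; beyond the scatter) and places compound 4 lowest of the four compounds. This position therefore accepts a side chain attached through a carbonyl, with one defined stereocentre less, and the number still falls. The step changes the attachment and the branching of the alkyl part together, and no measurement shown gives a reason for its size.

The compounds shown leave open how much of the step belongs to the carbonyl and how much to the shifted branching. Also open, on these data alone, is how a longer chain on the carbonyl, or a carboxylic acid in place of the end amine, would read in this assay at this position.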